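The compounds below may be only part of what the source reports. "The series", "measured", "known", "first", "only" and "open" are said of these compounds alone.

For the measured compounds named here, in a functional assay (strain AB) with Danio rerio as the target, read by microscopy, with a stated time of 1 h (on this read-out higher numbers stand for an effect only at larger amounts of compound and lower numbers for an effect already at smaller amounts), compound 1 (`C[N+]1(CC2CCCCC2)CCc2c(sc(NC(=O)Nc3ccc(Cl)cc3)c2C(N)=O)C1`) gives 100 nM and compound 2 (`C[N+]1(CC2CCC2)CCc2c(sc(NC(=O)Nc3ccc(Cl)cc3)c2C(N)=O)C1`) gives 210 nM as the higher of the two numbers so far. Compound 3 (`CC(C)(C)C[N+]1(C)CCc2c(sc(NC(=O)Nc3ccc(Cl)cc3)c2C(N)=O)C1`) has tert-butyl in place of cyclobutyl on a saturated chain carbon bound to an amine nitrogen in a ring, which can also be read as cyclobutylmethyl to neopentyl. Going by the values given here, only one measured step bears on this, the modest one with cyclobutyl in place of cyclohexyl (a 2.1-fold higher number from compound 1 to compound 2 (0.32 log units; beyond the scatter)). Among the compounds with values here, that step exchanges one ring for another, so it is an indirect guide, and no measured pair shows a ring giving way to an open group. With that modest step from compound 1 as the only reference and the heavy-atom count unchanged, no step beyond the scatter is expected in this assay. The expected step is small (a 1.0-fold higher number from compound 2 to compound 3 (0.02 log units; within the scatter)). The estimate for compound 3 is 220 nM with a range from 100 nM to 480 nM.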

Compound 3, half-maximal effective concentration: 290 nM
Estimate against measurement, compound 3: 1.3-fold (0.12 log units) below; the measured number falls inside the stated range.
By their numbers in this assay, from the lowest: compound 1; then compounds 2 and 3 (each within the scatter of the next).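

In this assay, tert-butyl in place of cyclobutyl gives a 1.4-fold higher number from compound 2 to compound 3 (0.14 log units; within the scatter) on a saturated chain carbon bound to an amine nitrogen in a ring, so at this place the read-out does not separate the open group from the four-membered ring. Set against cyclohexyl, tert-butyl gives a 2.9-fold higher number from compound 1 to compound 3 (0.46 log units; beyond the scatter) and this leaves compound 1 with the lowest of the three numbers. The compounds shown leave open how a phenyl group, a longer chain such as n-hexyl, or a group carrying a hydroxyl or an amine would read at this place. They also leave open whether an open chain with as many carbons as cyclohexyl would match compound 1. Nothing available here offers an explanation for these steps.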